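This account rests on a few compounds, and the source may have more. Where it says the series, first, only, none or still open, it means among the compounds named here.

Measured so far:

Compound 1 `CSc1nc(NCCCCNc2ccnc3cc(Cl)ccc23)c(C#N)c(-c2ccccc2)n1`: in an ADME assay on MDCK cells (Canis lupus familiaris) for cytotoxicity, read by microscopy (on this read-out higher numbers stand for lower toxicity in this test and lower numbers for higher toxicity in this test), compound 1 gives 20000 nM.
Compound 3 `CSc1nc(NCCCCNc2ccnc3cc(Cl)ccc23)c(C#N)c(-c2ccc([N+](=O)[O-])cc2)n1`: in this assay compound 3 gives 4000 nM.
Compound 2 `CSc1nc(-c2ccccc2)c(C#N)c(N2CCN(c3ccnc4cc(Cl)ccc34)CC2)n1`: in this assay compound 2 reaches only a limit, > 100000 nM, not a number.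

Compound 2 therefore stands at the upper edge of the numbers shown, at the limit of > 100000 nM in this assay, at which 1 of the 3 values shown sits, which tells only that its true number lies somewhere beyond that edge. Compound 4 `CSc1nc(-c2ccc([N+](=O)[O-])cc2)c(C#N)c(N2CCN(c3ccnc4cc(Cl)ccc34)CC2)n1` differs from compound 2 by nitro in place of hydrogen on an aromatic carbon. The same change has been measured once, as a 5.0-fold lower number from compound 1 to compound 3 (0.70 log units; beyond the scatter), a step beyond the scatter and towards higher toxicity. The step from compound 2 to compound 4 is expected to run the same way, a lower number in this assay, though since compound 2 only sets a limit the starting point is uncertain and compound 4 may itself still come out as a limit. The estimate for compound 4 is 50000 nM, between 15000 nM and 150000 nM, which means the expected step of an at least 2.0-fold lower number from compound 2 to compound 4 (0.30 log units; that floor lies within the scatter).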

Compound 4, minimum cytotoxic concentration: > 100000 nM
Compound 4: only a limit was reported (the forecaster's own chance of this, stated with the estimate: 40%); middle value at least 2.0-fold (0.30 log units) away from the limit.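

Compound 2 and compound 4 both report only a limit in this assay, so no step between them can be read: the limit of > 100000 nM in this assay, at which 2 of the 4 values shown sit.

The compounds shown leave open whether going from phenyl to 4-nitrophenyl changes the result at all between compound 2 and compound 4.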